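Swapping a fluorinated carbinol for a sulfonamide on the aryl ring

A few compounds are considered here, and "the series" means these few. Any claim that something is new, unique, unknown or untested is made for them only; others in the source may bear on it.

Compound 1 `CC#C[C@H]1CN(S(=O)(=O)c2ccc(N)nc2)CCN1c1ccc(C(O)(COC)C(F)(F)F)cc1`: 202 nM
Compound 2 `CC#C[C@H]1CN(S(=O)(=O)c2ccc(N)nc2)CCN1c1ccc(C(=O)NC)cc1`: 4050 nM
Compound 3 `CC#C[C@H]1CN(S(=O)(=O)c2ccc(N)nc2)CCN1c1ccc([C@@](O)(CO)C(F)(F)F)cc1`: 89 nM

In an assay on cells (Hepatocyte) for inhibition of glucokinase regulatory protein (Mus musculus), with stated times of 20 min and 40 min (a higher number here means that more compound is needed for the effect, a lower number that less compound is needed), compound 3 gives 89 nM, the lowest of the three numbers; its nearest neighbour is compound 1 with 202 nM and its furthest is compound 2 with 4050 nM. Compound 4 `CC#C[C@H]1CN(S(=O)(=O)c2ccc(N)nc2)CCN1c1ccc(S(=O)(=O)NCC2CC2)cc1` differs from compound 3 in one place: a group of 8 heavy atoms (4 carbon, 1 nitrogen, 2 oxygen, 1 sulfur; one three-membered non-aromatic ring of carbon only) in place of a group of 8 heavy atoms (3 carbon, 2 oxygen, 3 fluorine; no ring), on an aromatic carbon. For the measured compounds named here, the steps that bear on this are a 20-fold higher number from compound 1 to compound 2 (1.30 log units; beyond the scatter) and a 46-fold lower number from compound 2 to compound 3 (1.66 log units; beyond the scatter), both showing that removing the fluorinated carbinol for a smaller non-fluorinated group costs a great deal in this assay. Compound 4 is therefore expected to need more compound, an estimated 10-fold higher number from compound 3 to compound 4 (1.00 log units; beyond the scatter), giving compound 4 an estimated 900 nM with a range of 250 nM to 3000 nM.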

Compound 4, half-maximal effective concentration: 271 nM
Compound 4: the middle estimate sits 3.3-fold (0.52 log units) above what was measured, and the stated range covers the measured number.
By their numbers in this assay, from the lowest: compound 3; then compounds 1 and 4 (each within the scatter of the next); then compound 2.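

The (cyclopropylmethyl)sulfamoyl group carries no fluorine, yet in this assay it stays near the fluorinated carbinols (a 3.0-fold higher number from compound 3 to compound 4 (0.48 log units; beyond the scatter)) and (a 1.3-fold higher number from compound 1 to compound 4 (0.13 log units; within the scatter)), the latter step lying within the scatter. Against the other non-fluorinated group, the methylcarbamoyl of compound 2, it gains a great deal (a 15-fold lower number from compound 2 to compound 4 (1.17 log units; beyond the scatter)), so at this place, para to a large group, losing the fluorinated carbinol need not bring the large cost seen with methylcarbamoyl. No measurement here accounts for this difference.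

The compounds shown leave open whether the gain belongs to the sulfamoyl link or to the cyclopropylmethyl chain. A methylsulfamoyl group and a (cyclopropylmethyl)carbamoyl group would separate the two.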